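The compounds below may be only part of what the source reports. "The series", "measured", "known", "first", "only" and "open" are said of these compounds alone.

Measured in an ADME assay on MT2 cells (Homo sapiens) for cytotoxicity, read by XTT assay, with a stated time of 4 days (a higher number here means that more compound is tolerated, a lower number that less compound is tolerated), for the half-maximal cytotoxic concentration:
- Compound 1 `Cc1ccc(NC(=O)C(=O)NC(c2nc(C)c(CCO)s2)C2CCCCN2)c(F)c1` gives > 78800 nM as a limit
- Compound 2 `Cc1nc(C(NC(=O)C(=O)Nc2ccc(Cl)c(F)c2)C2CCCCN2)sc1CCO` gives > 41000 nM as a limit
- Compound 3 `Cc1nc(C(NC(=O)C(=O)NC2CCCCCC2)C2CCCCN2)sc1CCO` gives 60000 nM as a number

Going by the values given here, compound 3 at 60000 nM holds the only number in this set. The other two values are limits. Compound 4 `Cc1nc(C(NC(=O)C(=O)Nc2ccc(F)c(Cl)c2)C2CCCCN2)sc1CCO` is the next to be read. The change is 3-chloro-4-fluorophenyl in place of cycloheptyl on an amide-type nitrogen and it returns an aromatic ring to the amide-type nitrogen, as in compound 1 and compound 2.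

Few steps bear on this change, and they must be read in the opposite sense. The only one with a size is an at least 1.3-fold lower number from compound 1 to compound 3 (0.11 log units; that floor lies within the scatter) and it gives a floor alone. Compound 2 is the closest neighbour, with the same two halogens on its phenyl ring. Its link is a step that the limit leaves unreadable from compound 2 to compound 3 and so offers no size. The comparison a step that the two limits leave unreadable from compound 1 to compound 2 adds nothing further.

In this assay no step beyond the scatter is therefore expected. The expected change is a 1.2-fold higher number from compound 3 to compound 4 (0.07 log units; within the scatter) with a small rise as the likelier direction. The estimate for compound 4 is 70000 nM with an expected range of 30000 nM to 150000 nM and a report as a limit alone is quite possible.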

Compound 4, half-maximal cytotoxic concentration: 94700 nM
Compound 4: middle estimate off by 1.4-fold (0.13 log units), on the low side; the measured number falls inside the stated range.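

In this assay, going by these compounds alone, the exchange of cycloheptyl for 3-chloro-4-fluorophenyl on an amide-type nitrogen gives a 1.6-fold higher number from compound 3 to compound 4 (0.20 log units; within the scatter) and this is the first step at this position with a full size rather than a floor, so an aromatic ring and a seven-membered non-aromatic ring are not told apart here. The steps that link compound 4 to compound 1 and to compound 2 cannot be read, as the values of compound 1 and compound 2 are limits, so the pair with the same two halogens on the phenyl ring gives no comparison. Nothing measured here gives a cause for the step from cycloheptyl to 3-chloro-4-fluorophenyl.

Within the data shown here, with only two numbers and no step beyond the scatter, it stays open whether any group on this amide-type nitrogen moves the read-out in this assay at all. A pyridine ring, a phenyl ring that carries a carboxylic acid, or a longer chain that ends in an amine would test this position with groups unlike the carbon rings and halogens shown so far.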